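The source may report more compounds than this note shows. Statements on the series, on what has been measured and on what is new or still open speak of the compounds shown alone.

Compound 2 `Cc1cccc(C(=O)N2CCc3nc(C#Cc4ccccc4)sc3C2)n1` carries a 6-methylpyridin-2-yl group on a carbonyl carbon whose other neighbour is an amide-type nitrogen in a ring of the shared core. In an assay on HEK293 cells for negative allosteric modulation of metabotropic glutamate receptor 5 (Homo sapiens), read by FLIPR, with a stated time of 1 h (on this read-out lower numbers stand for stronger inhibition and higher numbers for weaker inhibition), compound 2 gives > 10000 nM, which is a limit of the assay rather than a number. Compound 1 `O=C(CC1CCOCC1)N1CCc2nc(C#Cc3ccccc3)sc2C1` has (oxan-4-yl)methyl in the same place. In this assay compound 1 gives > 10000 nM, again a limit. Both values sit at the limit of > 10000 nM in this assay, at which 2 of the 2 values shown sit, so the step that the two limits leave unreadable from compound 1 to compound 2 cannot be read in either size or direction. Compound 3 `Cc1nc(C(=O)N2CCc3nc(C#Cc4ccccc4)sc3C2)cs1` differs from compound 2 by 2-methyl-1,3-thiazol-4-yl in place of 6-methylpyridin-2-yl on a carbonyl carbon. Going by the values given here, no measured step tells how swapping one small aromatic ring for another at this carbonyl carbon moves the read-out, and the single neighbouring step was unreadable, both of its ends being limits. The only anchor is the limit given by compound 2 itself. Compound 3 is therefore expected to remain weak, at an estimated 9000 nM with a range from 2500 nM to 30000 nM, most likely reported again as a limit. The step of an at least 1.1-fold lower number from compound 2 to compound 3 (0.04 log units; that floor lies within the scatter) is expected to stay within the usual scatter.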

Compound 3, half-maximal inhibitory concentration: > 10000 nM
Compound 3 was reported as a limit (the forecaster's own chance of this, stated with the estimate: 65%); at least 1.1-fold (0.04 log units) between middle value and limit.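

Compound 3 joins compound 1 and compound 2 as a limit rather than a number in this assay, so no step among these three compounds can be read in size or direction: the limit of > 10000 nM in this assay, at which 3 of the 3 values shown sit.

The compounds shown leave open whether any group on this carbonyl carbon of the shared core gives a measurable number in this assay, and how such groups would compare.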